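A few compounds are considered here, and "the series" means these few. Any claim that something is new, unique, unknown or untested is made for them only; others in the source may bear on it.

Growth inhibition measured in a functional assay on RS4-11 cells (Homo sapiens) for inhibition, read by CCK-8 assay, with a stated time of 48 h, tested at 20 uM; a lower number here means less inhibition of growth, a higher number more inhibition of growth at the concentration tested:

- compound 1 `COc1ccc(S(=O)(=O)Oc2ccccc2/C=C(\C#N)C(=O)Nc2nnc(-c3cccs3)s2)cc1`: 76%
- compound 2 `N#C/C(=C\c1ccccc1OS(=O)(=O)c1ccc([N+](=O)[O-])cc1)C(=O)Nc1nnc(-c2cccs2)s1`: 40%
- compound 3 `N#C/C(=C\c1ccccc1OS(=O)(=O)c1ccc(Cl)cc1)C(=O)Nc1nnc(Cc2cccc3ccccc23)s1`: 68%

Compound 2 stands lowest of the three, and the gaps to compound 3 and to compound 1 both lie beyond the scatter. The next compound, compound 4 `N#C/C(=C\c1ccccc1OS(=O)(=O)c1ccc([N+](=O)[O-])cc1)C(=O)Nc1nnc(Cc2ccccc2)s1`, keeps the nitro group of compound 2 and changes one group on the shared core: benzyl in place of thiophen-2-yl on an aromatic carbon.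

Within the data shown here, only one measured step is available, a number 36 percentage points lower from compound 1 to compound 2 (beyond the scatter). It is large, but it records nitro in place of methoxy, at another place in the molecule, so it shows that a single change can move this read-out a long way without giving the size of the present one. Compound 3 also lacks both the thiophen-2-yl and the nitro group and gives 68%, but it differs from compound 2 in more than one place, which makes it only a weak hint of an upward move. The expected change is therefore small and upward, a number 6 percentage points higher from compound 2 to compound 4 (within the scatter), and is not expected to exceed the scatter. For compound 4 the estimated value is 46%, with an expected range from 26% to 66%.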

Compound 4, percent growth inhibition at one concentration: 57%
Beside the measured number, compound 4's estimate is 11 percentage points below it, and the stated range covers the measured number.
By their numbers in this assay, from the lowest: compound 2; then compound 4; then compounds 3 and 1 (each within the scatter of the next).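

In this assay, the aromatic carbon next to the ring nitrogen and next to the ring sulfur proves to be a place where one change moves the read-out: benzyl in place of thiophen-2-yl gives a number 17 percentage points higher from compound 2 to compound 4 (beyond the scatter) with the nitro group kept. Among these compounds, until now the only single change that could be read was nitro in place of methoxy, a number 36 percentage points lower from compound 1 to compound 2 (beyond the scatter) at another place in the molecule, so the new step adds a second site at which growth inhibition responds. No measured property is at hand that would account for this step.

On these data alone, what stays open is whether the same step would appear with methoxy in place of nitro, and whether the rise belongs to the extra carbon of benzyl or to the change from a five-membered aromatic ring with one hetero atom to a six-membered aromatic ring of carbon only, a question that phenyl at this place would help to settle. Also open, as far as these compounds go, is how a longer chain such as 2-phenylethyl, or an amine such as piperidin-1-yl, would read here.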